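Swapping the heteroaryl arm on a shared piperidinyl-pyridazine core

A few compounds are considered here, and "the series" means these few. Any claim that something is new, unique, unknown or untested is made for them only; others in the source may bear on it.

Measured so far:
compound 1 `Brc1ccccc1OC1CCN(c2ccc(-n3ccnc3)nn2)CC1` gives 5 nM
compound 2 `OCc1nnc(-c2ccc(N3CCC(Oc4ccccc4C(F)(F)F)CC3)nn2)s1` gives 3.2 nM

In an assay on microsomes from liver for inhibition of acyl-CoA desaturase 1 (Rattus norvegicus) (on this read-out lower numbers stand for stronger inhibition and higher numbers for weaker inhibition), compound 2 shows the lowest of the two numbers, yet compound 1 sits so close that the two lie within the scatter of each other. Compound 3 `FC(F)(F)c1ccccc1OC1CCN(c2ccc(-c3nnco3)nn2)CC1` carries 1,3,4-oxadiazol-2-yl in place of 5-(hydroxymethyl)-1,3,4-thiadiazol-2-yl on an aromatic carbon. Among the compounds with values here, no measured pair shows this exchange, so the account expects a step of a 1.9-fold higher number from compound 2 to compound 3 (0.27 log units; within the scatter), a modest move towards weaker inhibition that may still fall inside the scatter. In this assay compound 3 is therefore estimated at 6 nM, with a range from 1.5 nM to 25 nM.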

Compound 3, half-maximal inhibitory concentration: 22 nM
Compound 3: the middle estimate sits 3.7-fold (0.56 log units) below what was measured; low and high end bracket the measured number.
By their numbers in this assay, from the lowest: compounds 2 and 1 (each within the scatter of the next); then compound 3.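

In this assay the 1,3,4-oxadiazol-2-yl in place of 5-(hydroxymethyl)-1,3,4-thiadiazol-2-yl on this aromatic carbon brings a 6.9-fold higher number from compound 2 to compound 3 (0.84 log units; beyond the scatter) and so marks this position as sensitive to the arm it carries. Both arms are five-membered aromatic rings with 3 hetero atoms, so sharing that ring count does not keep the number low here. The exchange removes the hydroxymethyl group and replaces the ring sulfur with oxygen in one step, leaving open which of these changes matters; a 5-(hydroxymethyl)-1,3,4-oxadiazol-2-yl arm would separate them. Nothing measured here accounts for the loss.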